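The source may hold more compounds than are shown below. What is called first, only, known or untested is meant among the compounds shown, and "the series" means these compounds.

Compound 1 `COc1cc2c(Oc3ccc(NC(=O)c4nnn(-c5ccccc5)c4C)cc3F)ccnc2cc1OCCCN1CCCCC1` is the starting point of this account. In a functional assay on NCI-H460 cells (Homo sapiens) for cytotoxicity, read by MTT assay, with a stated time of 72 h (on this read-out lower numbers stand for stronger inhibition and higher numbers for weaker inhibition), compound 1 gives 220 nM. Among the measured compounds shown here, its only measured companion, compound 2 `COc1cc2c(Oc3ccc(NC(=O)c4nnn(-c5ccccc5C(F)(F)F)c4C)cc3F)ccnc2cc1OCCCN1CCCCC1`, gives 280 nM in this assay; the step of a 1.3-fold higher number from compound 1 to compound 2 (0.10 log units; within the scatter) carries trifluoromethyl in place of hydrogen on an aromatic carbon and stays within the scatter, so on the numbers so far compound 1 has no neighbour it can be told apart from.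

The next compound, compound 3 `COc1cc2c(Oc3ccc(NC(=O)c4nnn(-c5ccccc5)c4C)cc3F)ccnc2cc1OCCCN1CCC(C)CC1`, differs from compound 1 by methyl in place of hydrogen on a saturated ring carbon. The change sits on the saturated six-membered ring with one nitrogen, three ring bonds from the ring nitrogen, and reads as piperidin-1-yl to 4-methylpiperidin-1-yl. For the measured compounds named here, no measured step touches that ring: the one step in hand, from compound 1 to compound 2, alters an aromatic position far from it and itself stays within the scatter. Nothing in the data therefore argues for a step beyond the scatter in this assay, in either direction. Compound 3 is accordingly expected to give about 250 nM, within a range of 110 nM to 560 nM, which would mean an expected step of a 1.1-fold higher number from compound 1 to compound 3 (0.06 log units; within the scatter).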

Compound 3, half-maximal inhibitory concentration: 170 nM
The estimate for compound 3 lay 1.5-fold (0.17 log units) above the measured number; the measured number falls inside the stated range.
By their numbers in this assay, from the lowest: compounds 3, 1 and 2 (each within the scatter of the next).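

In this assay, among the compounds shown here, the step of a 1.3-fold lower number from compound 1 to compound 3 (0.11 log units; within the scatter) is the first measured change on the saturated ring, and it shows that a methyl can stand on this ring carbon, three ring bonds from the ring nitrogen, without a difference that can be told from the scatter. The earlier step, trifluoromethyl in place of hydrogen on an aromatic carbon, also stays within the scatter, so neither of the two changes in hand, one on an aromatic carbon and one on the saturated ring, separates its compounds on this read-out. Nothing available bears on why this step is so small, and the size of the step is all that can be said of it.

The compounds shown leave open whether a longer chain such as ethyl, a hydroxyl or a dimethylamino group on the same ring carbon would keep the number within the scatter of compound 1. They also leave open whether a morpholine in place of the piperidine would do so, since a single methyl is all that has been placed on this ring.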